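Replacing the amide of compound 3 with a pyridine ring

The source may hold more compounds than are shown below. What is called first, only, known or untested is meant among the compounds shown, and "the series" means these compounds.

Compound 1 `CS(=O)(=O)c1coc(C(=O)CCCCCCc2ccccc2)n1` and compound 2 `CC(C)(C)C(=O)c1coc(C(=O)CCCCCCc2ccccc2)n1` share a core with compound 3 `CNC(=O)c1coc(C(=O)CCCCCCc2ccccc2)n1` and differ only in the group on the five-membered ring. In an assay on HEK-293T cells for inhibition of diacylglycerol lipase-alpha (Homo sapiens), read by colorimetric assay (on this read-out higher numbers stand for weaker inhibition and lower numbers for stronger inhibition), compound 1 gives 389 nM and compound 2 gives 479 nM. Compound 3 reaches only the limit of this assay, > 10000 nM, so for it no number is known, only that it sits at the limit of > 10000 nM in this assay, at which 1 of the 3 values shown sits. The steps of an at least 25-fold higher number from compound 1 to compound 3 (1.41 log units; beyond the scatter) and an at least 20-fold higher number from compound 2 to compound 3 (1.31 log units; beyond the scatter) are both large. Compound 4 `O=C(CCCCCCc1ccccc1)c1nc(-c2ccccn2)co1` makes the change (pyridin-2-yl in place of methylcarbamoyl on an aromatic carbon). Since that removes the group whose entry cost so much, a large step back toward the numbers of compound 1 and compound 2 is expected, so compound 4 is estimated at 600 nM (range 120 nM to 5000 nM), a step of an at least 16-fold lower number from compound 3 to compound 4 (1.22 log units; beyond the scatter).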

Compound 4, half-maximal inhibitory concentration: > 10000 nM
Compound 4: no number, only a limit; the forecaster's own chance of this, stated with the estimate: 20%; middle value at least 16-fold (1.22 log units) from the limit.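

Pyridin-2-yl on this aromatic carbon does not bring back the inhibition of the earlier compounds: the change gives an at least 20-fold higher number from compound 2 to compound 4 (1.31 log units; beyond the scatter) and an at least 25-fold higher number from compound 1 to compound 4 (1.41 log units; beyond the scatter). Taking away methylcarbamoyl, with its hydrogen-bond donor, was thus not enough on its own to recover those values. Compound 4 gives only a limit, > 10000 nM, not a number, so its step from compound 3 cannot be read: the limit of > 10000 nM in this assay, at which 2 of the 4 values shown sit.

The compounds shown leave open whether a phenyl ring or a methyl ester on this carbon would return to the range of compound 1 and compound 2. On these data alone, the true values of compound 3 and compound 4 also remain unknown.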